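From tert-butoxycarbonyl to isopropylcarbonyl on a shared core

The source may hold more compounds than are shown below. What is called first, only, known or untested is meant among the compounds shown, and "the series" means these compounds.

Compound 1 `CN(C)CC(=O)N1CCC(NS(=O)(=O)c2cc(S(=O)(=O)c3ccccc3)ccc2C(F)(F)F)CC1`: in a functional assay on U2OS cells for antagonist activity at proto-oncogene Wnt-3 (Homo sapiens), read by a luciferase reporter, with a stated time of 18 h (on this read-out lower numbers stand for an effect already at smaller amounts and higher numbers for an effect only at larger amounts of compound), compound 1 gives 280 nM.
Compound 2 `O=C(Cn1ccnc1)N1CCC(NS(=O)(=O)c2cc(S(=O)(=O)c3ccccc3)ccc2C(F)(F)F)CC1`: in this assay compound 2 gives 230 nM.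
Compound 3 `CC(C)(C)OC(=O)N1CCC[C@@H]1C(=O)N1CCC(NS(=O)(=O)c2cc(S(=O)(=O)c3ccccc3)ccc2C(F)(F)F)CC1`: in this assay compound 3 gives 210 nM.

Compound 3 has the lowest of the three numbers, yet both steps toward it, a 1.3-fold lower number from compound 1 to compound 3 (0.12 log units; within the scatter) and a 1.1-fold lower number from compound 2 to compound 3 (0.04 log units; within the scatter), fall within the scatter, as does a 1.2-fold lower number from compound 1 to compound 2 (0.09 log units; within the scatter), so no order among the three can be read. Compound 4 `CC(C)C(=O)N1CCC[C@H]1C(=O)N1CCC(NS(=O)(=O)c2cc(S(=O)(=O)c3ccccc3)ccc2C(F)(F)F)CC1` differs from compound 3 in one place: 1-(isopropylcarbonyl)pyrrolidin-2-yl in place of 1-(tert-butoxycarbonyl)pyrrolidin-2-yl on a carbonyl carbon. Going by the values given here, none of the measured steps bears on this change; all three vary the group on the carbonyl carbon and none moves the number beyond the scatter. Lacking a comparable step, the expected step of no change at the digits printed from compound 3 to compound 4 (within the scatter) in this assay is taken to stay within the scatter. Compound 4 is therefore estimated at 210 nM, with a range from 90 nM to 500 nM.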

Compound 4, half-maximal effective concentration: 90 nM
The estimate for compound 4 lay 2.3-fold (0.37 log units) above the measured number; the range from low to high includes it.
By their numbers in this assay, from the lowest: compound 4; then compounds 3, 2 and 1 (each within the scatter of the next).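

In this assay, going by these compounds alone, the group on the carbonyl carbon moves the number beyond the scatter for the first time: a 2.3-fold lower number from compound 3 to compound 4 (0.37 log units; beyond the scatter) and a 2.6-fold lower number from compound 2 to compound 4 (0.41 log units; beyond the scatter) and a 3.1-fold lower number from compound 1 to compound 4 (0.49 log units; beyond the scatter) are all modest steps. Compound 4 thus stands apart from all three earlier compounds, which could not be ordered among themselves. Nothing available here accounts for this change.

From the compounds shown here alone, the stereocentre is drawn with opposite configuration in compound 3 and compound 4, so its share in the step stays open. So does the outcome with a free amine on the pyrrolidine nitrogen or a longer acyl chain there.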